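A few compounds are considered here, and "the series" means these few. Any claim that something is new, unique, unknown or untested is made for them only; others in the source may bear on it.

Working notes on the series, all read in a functional assay on cells (Cancer cell lines, Homo sapiens) for inhibition; a lower number here means a stronger inhibitor of growth, a higher number a weaker inhibitor of growth. Compound 1 (`Cc1cc(-c2nc3sc(C)cn3c2/C=N/NC(=N)N)c(C)s1`) gives 9770 nM, compound 2 (`Cc1cn2c(/C=N/NC(=N)N)c(-c3ccsc3)nc2s1`) gives 13800 nM and compound 3 (`N=C(N)N/N=C/c1c(-c2cccs2)nc2sccn12`) gives 12900 nM. Compound 3 lies within the scatter of both others, so the three values form one group with no order among them.

Compound 4 (`Cc1cn2c(/C=N/NC(=N)N)c(-c3cccs3)nc2s1`) differs from compound 3 at one place: methyl in place of hydrogen on an aromatic carbon. This is methyl in place of hydrogen on an aromatic carbon, next to the ring sulfur of a five-membered aromatic ring with 1 nitrogen and 1 sulfur.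

Within the data shown here, no measured pair isolates this change. Among the measured compounds shown here, the only measured step, a 1.4-fold higher number from compound 1 to compound 2 (0.15 log units; within the scatter), puts thiophen-3-yl in place of 2,5-dimethylthiophen-3-yl. It concerns another place, so it serves only as a rough guide to size. Compound 1 and compound 2 both carry the entering methyl on the shared core and compound 3 does not, yet all three values stay close.

No step beyond the scatter is therefore expected in this assay, and neither direction is favoured. The expected step is a 1.1-fold lower number from compound 3 to compound 4 (0.05 log units; within the scatter). The estimate for compound 4 is 11500 nM, with an expected range of 6000 nM to 21000 nM.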

Compound 4, concentration for 50% growth inhibition: 7760 nM
Estimate against measurement, compound 4: 1.5-fold (0.17 log units) above; the range from low to high includes it.
By their numbers in this assay, from the lowest: compounds 4, 1, 3 and 2 (each within the scatter of the next).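

In this assay, the pair of compound 3 and compound 4 isolates methyl in place of hydrogen on an aromatic carbon, next to the ring sulfur, and gives a 1.7-fold lower number from compound 3 to compound 4 (0.22 log units; within the scatter) for this change alone. With that methyl fixed on the shared core, the thiophene substituent can also be read directly: a 1.8-fold lower number from compound 2 to compound 4 (0.25 log units; within the scatter) and a 1.3-fold lower number from compound 1 to compound 4 (0.10 log units; within the scatter) leave thiophen-2-yl, thiophen-3-yl and 2,5-dimethylthiophen-3-yl unseparated in this series. No information at hand bears on the cause of these small steps.

From the compounds shown here alone, the methyl step rests on one pair carrying thiophen-2-yl, so its size with thiophen-3-yl or 2,5-dimethylthiophen-3-yl remains open. Among these compounds, also open is whether an ethyl group, an amine, a carboxylic acid or a longer chain at this same aromatic carbon would stay within the scatter of these four compounds or produce the first clear step.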